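This account rests on a few compounds, and the source may have more. Where it says the series, first, only, none or still open, it means among the compounds named here.

In a functional assay on MCF7 cells (Homo sapiens) for inhibition, read by radiometric assay and XTT assay (on this read-out higher numbers stand for weaker inhibition and lower numbers for stronger inhibition), compound 3 (`C=CCNC(=O)COC1=CC(=O)S[C@]1(C)CCCCCCCC`) gives 12.1 ug/mL. Compound 1 (`CCCCCCCC[C@@]1(C)SC(=O)C=C1OC`) gives 16.4 ug/mL, which lies within the usual scatter of compound 3, so the two cannot be told apart on these numbers. Compound 2 (`CCCCCC[C@@]1(C)SC(=O)C=C1OCC(=O)NCC(=O)OC`) gives 40.5 ug/mL, a higher number and so weaker inhibition, and its gap to compound 3 lies beyond the scatter.

The next compound, compound 4 (`C=CCOC(=O)OC1=CC(=O)S[C@]1(C)CCCCCCCC`), keeps the core of compound 3 and changes one group: allyloxycarbonyl in place of (allylcarbamoyl)methyl on an oxygen on an unsaturated carbon.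

Among the measured compounds shown here, only one measured step bears on this change, since it also alters the group carried on that oxygen: a 1.4-fold lower number from compound 1 to compound 3 (0.13 log units; within the scatter). That step stays within the scatter, even though it adds an allylcarbamoyl group. Compound 2 differs from compound 3 in more than one place, so it offers no clean comparison. One small step is thin evidence, and the incoming group has not been measured in any other compound here. Even so, no shift beyond the scatter is expected in this assay, and the expected step is a 1.2-fold higher number from compound 3 to compound 4 (0.06 log units; within the scatter). For compound 4 the estimated value is 14 ug/mL, with an expected range from 6 ug/mL to 32 ug/mL.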

Compound 4, half-maximal inhibitory concentration: 37.3 ug/mL
For compound 4 the middle estimate is 2.7-fold (0.43 log units) below the measured one; measured number above the stated range.
By their numbers in this assay, from the lowest: compounds 3 and 1 (each within the scatter of the next); then compounds 4 and 2 (each within the scatter of the next).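

At this position, the oxygen on an unsaturated carbon, the earlier step gave no sign that the group mattered in this assay: a 1.4-fold lower number from compound 1 to compound 3 (0.13 log units; within the scatter) is a change too small to separate the two compounds. Allyloxycarbonyl behaves differently, giving a 3.1-fold higher number from compound 3 to compound 4 (0.49 log units; beyond the scatter) and a 2.3-fold higher number from compound 1 to compound 4 (0.36 log units; beyond the scatter) as well, so it weakens inhibition relative to both the (allylcarbamoyl)methyl group and the methyl group, and the position is therefore not indifferent to what it carries. The groups exchanged between compound 3 and compound 4 differ in several counted ways, including 1 hydrogen-bond donor in the group that leaves and 0 in the group that enters, and nothing measured here shows which of these differences, if any, accounts for the higher number.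

An acetyl group on the same oxygen would help show whether any carbonyl attached directly there gives a similar number or whether the allyloxy part is also involved. A chain ending in an amine or a carboxylic acid in place of the allyl end would test how far this position tolerates other groups.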